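This account rests on a few compounds, and the source may have more. Where it says the series, first, only, none or still open, it means among the compounds named here.

Notes on the series in a functional assay on CHO cells for agonist activity at Alpha-1B adrenergic receptor (Homo sapiens), read by FLIPR and calcium flux; on this read-out higher numbers stand for an effect only at larger amounts of compound and lower numbers for an effect already at smaller amounts.

Compound 1, `COc1c(Cl)ccc2c1CCC2c1ncc[nH]1`, carries a methoxy group on its bicyclic core. In this assay compound 1 gives > 10000 nM, which is a limit of the assay and not a measured number. Among the measured compounds shown here, compound 2, `Cc1c(OCC2=NCCN2)ccc(Cl)c1NS(C)(=O)=O`, is the only other member measured so far. In this assay compound 2 gives > 10000 nM, again a limit rather than a number. Both values therefore sit at the same boundary: the limit of > 10000 nM in this assay, at which 2 of the 2 values shown sit. For the measured compounds named here, compound 1 thus stands at the edge of the assay's range, and nothing measured so far places any member of the series inside it.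

Compound 3, `Clc1ccc2c(c1-c1cn[nH]c1)CCC2c1ncc[nH]1`, is not yet measured. It differs from compound 1 in one place: 1H-pyrazol-4-yl in place of methoxy on an aromatic carbon. Going by the values given here, no step between two measured compounds is available, so the size of this change cannot be read from the series. With compound 1 at the assay limit, the expectation for compound 3 is a step of no clear direction, a step that the limit leaves unreadable from compound 1 to compound 3, and most likely a result that stays at the limit. The estimate for compound 3 is 15000 nM, with a range from 3000 nM to 60000 nM.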

Compound 3, half-maximal effective concentration: > 10000 nM
Compound 3: a limit, no number; the forecaster's own chance of this, stated with the estimate: 70%; the middle value is on the limit's open side.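

In this assay compound 3 gives > 10000 nM, a limit of the assay and not a number. No step can be read between compound 1 and compound 3, whose results share one boundary: the limit of > 10000 nM in this assay, at which 3 of the 3 values shown sit.

The compounds shown leave open what value any member of the series would take inside the range of this assay.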